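A Methyl on the Core: Expectation for Compound 4

The source may hold more compounds than are shown below. What is called first, only, known or untested is meant among the compounds shown, and "the series" means these compounds.

Measured so far:
compound 1 `CC(C)OC(=O)N1CCC(Oc2ncnc3c2CCN3c2ccc(S(C)(=O)=O)cc2F)CC1` gives 50.1 nM
compound 2 `CCS(=O)(=O)N1CCC(Oc2ncnc3c2CCN3c2ccc(S(C)(=O)=O)cc2F)CC1` gives 1580 nM
compound 3 `CN(C)C(=O)CN1CCC(Oc2ncnc3c2CCN3c2ccc(S(C)(=O)=O)cc2F)CC1` gives > 10000 nM

In a functional assay on CHO-K1 cells for agonist activity at Glucose-dependent insulinotropic receptor (Homo sapiens), read by a luciferase reporter, with a stated time of 5 h (on this read-out lower numbers stand for an effect already at smaller amounts and higher numbers for an effect only at larger amounts of compound), compound 1 stands lowest of the two numbers that are known. The nearest is compound 2, and the step of a 32-fold higher number from compound 1 to compound 2 (1.50 log units; beyond the scatter) is large. For compound 3 the reading is not a number but a limit: the limit of > 10000 nM in this assay, at which 1 of the 3 values shown sits. The steps of an at least 190-fold higher number from compound 1 to compound 3 (2.30 log units; beyond the scatter) and an at least 6.3-fold higher number from compound 2 to compound 3 (0.80 log units; beyond the scatter) are therefore at least as large as stated.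

All three measured steps exchange the group on the ring nitrogen of the piperidine, with compound 1 keeping the isopropoxycarbonyl there. Compound 4 `Cc1nc(OC2CCN(C(=O)OC(C)C)CC2)c2c(n1)N(c1ccc(S(C)(=O)=O)cc1F)CC2` keeps that isopropoxycarbonyl unchanged and differs from compound 1 only in methyl in place of hydrogen on an aromatic carbon. Within the data shown here, no measured step touches this aromatic carbon, so none of them bears on the change; the three known steps speak only to the nitrogen substituent.

With nothing pulling either way, the step from compound 1 to compound 4 is expected to be a 1.0-fold lower number from compound 1 to compound 4 (0.00 log units; within the scatter), within the scatter. Compound 4 is estimated at 50 nM, with a range from 12 nM to 250 nM.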

Compound 4, half-maximal effective concentration: 100 nM
Beside the measured number, compound 4's estimate is 2.0-fold (0.30 log units) below it; the measured number falls inside the stated range.
By their numbers in this assay, from the lowest: compounds 1 and 4 (each within the scatter of the next); then compound 2. At a limit, above all of these: compound 3.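

In this assay, the aromatic carbon between two ring nitrogen atoms, which no earlier comparison touched, now has a reading of its own: methyl in place of hydrogen there gives a 2.0-fold higher number from compound 1 to compound 4 (0.30 log units; within the scatter) and so does not move the number beyond the usual variation between repeats. This position therefore takes one added methyl, with the isopropoxycarbonyl kept on the ring nitrogen, without a step beyond the scatter, whereas exchanging the group on that nitrogen gave a 32-fold higher number from compound 1 to compound 2 (1.50 log units; beyond the scatter) and a much clearer change. The measurements shown give no property of the methyl group that could explain this outcome, so the result describes what happens at this carbon and not why.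

A single methyl says little about what other groups would do at the same carbon, and an ethyl chain, a methoxy group, an amine or a trifluoromethyl group could read quite differently. From the compounds shown here alone, it also remains open whether methyl at this carbon would give a similar step with ethylsulfonyl or (dimethylcarbamoyl)methyl on the ring nitrogen in place of the isopropoxycarbonyl.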